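Three lactone ethers, and a fourth with one more double bond

The compounds below may be only part of what the source reports. "The series", "measured", "known", "first", "only" and "open" are said of these compounds alone.

Compound 1 `C/C(=C\COc1c(Cl)cccc1Cl)CC/C=C(\C)C1CC(=O)C(C)(C)O1` gives 59.9 ug/mL in a functional assay on Raji cells (Homo sapiens) for inhibition; on this read-out higher numbers stand for weaker inhibition and lower numbers for stronger inhibition. Compound 2 `C/C(=C\COc1ccc2ccccc2c1)CC/C=C(\C)C1CC(=O)C(C)(C)O1` gives 47.9 ug/mL in this assay. Compound 3 `C/C(=C\COc1ccccc1)CC/C=C(\C)C1=CC(=O)C(C)(C)O1` gives 40.3 ug/mL in this assay.

All three share a long branched chain that carries an aryl ether at one end and a small oxygen-containing five-membered ring at the other. Compound 2 stands second highest of the three numbers, but its neighbours lie close on both sides: compound 3 is within the scatter of it, and so is compound 1. Among the measured compounds shown here, on these three values alone no compound can be called stronger or weaker than another.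

Compound 4 `C/C(=C\COc1ccc2ccccc2c1)CC/C=C(\C)C1=CC(=O)C(C)(C)O1` has not yet been measured in this assay. It differs from compound 2 only at the ring end of the chain: a group of 8 heavy atoms (6 carbon, 2 oxygen; one five-membered non-aromatic ring with 1 hetero atom) in place of a group of 8 heavy atoms (6 carbon, 2 oxygen; one five-membered non-aromatic ring with 1 hetero atom), on a double-bonded chain carbon bound to a double-bonded chain carbon and a saturated chain carbon. The entering group has one more double bond outside aromatic rings than the leaving group; compound 3 carries this same unsaturated ring and gives 40.3 ug/mL, within the scatter of compound 2. Because compound 3 gives 40.3 ug/mL and compound 2 gives 47.9 ug/mL within the scatter of each other, the step is expected to be small, with no clear direction beyond the scatter, so the estimated step from compound 2 to compound 4 is a 1.1-fold lower number from compound 2 to compound 4 (0.06 log units; within the scatter). Compound 4 is therefore expected to give about 42 ug/mL, with a likely range from 20 ug/mL to 90 ug/mL.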

Compound 4, half-maximal inhibitory concentration: 63.2 ug/mL
Estimate against measurement, compound 4: 1.5-fold (0.18 log units) below; the measured number falls inside the stated range.
By their numbers in this assay, from the lowest: compounds 3, 2, 1 and 4 (each within the scatter of the next).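

Among the compounds shown here, this pair is the first in the set to differ in only one place, so the ring end of the chain can now be judged on its own in this assay: replacing 5,5-dimethyl-4-oxooxolan-2-yl with a ring of the same size that carries one more double bond gives a 1.3-fold higher number from compound 2 to compound 4 (0.12 log units; within the scatter). With this aryl ether, the added double bond therefore has no effect that can be told from the scatter at this place, on a double-bonded chain carbon bound to a double-bonded chain carbon and a saturated chain carbon. No measurement shown here bears on this result or offers an explanation for it.

The compounds shown leave open whether the same exchange would read the same way with the aryl ethers of compound 1 and compound 3, as neither has a partner that differs from it in this one place. Also open, as far as these compounds go, is whether an amine or a carboxylic acid at the ring end, or a longer chain, would shift the number in this assay beyond the scatter.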